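Cell Tolerance of Three Measured Compounds and One Untested Analogue

This account rests on a few compounds, and the source may have more. Where it says the series, first, only, none or still open, it means among the compounds named here.

Compound 1, `CCCCC(c1cc2ccc(C)cc2[nH]c1=O)N(Cc1ccc(F)cc1)Cc1ccc(C(C)C)cc1`: > 33000 nM in a toxicity assay on MDCK cells (Canis lupus familiaris) for cytotoxicity, read by crystal violet staining, with a stated time of 48 h; a higher number here means that more compound is tolerated, a lower number that less compound is tolerated
Compound 2, `Cc1ccc2cc(CN(Cc3ccc(C(C)(C)C)cc3)C3CCCC3)c(=O)[nH]c2c1`: > 10000 nM in this assay
Compound 3, `CCOc1ccc(CN(Cc2ccc(C(C)(C)C)cc2)Cc2cc3cc(C)ccc3[nH]c2=O)cc1`: > 10000 nM in this assay

All three values in this assay are limits of the assay rather than numbers. Compound 3 stands at the limit of > 10000 nM in this assay, at which 2 of the 3 values shown sit, together with compound 2. Compound 1 stands at the limit of > 33000 nM in this assay, at which 1 of the 3 values shown sits. Going by the values given here, no step between two measured compounds can therefore be read from these numbers; they show only that none of the three was toxic within the tested range.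

Compound 4, `Cc1ccc2[nH]c(=O)c(CN(Cc3ccc(SC(F)(F)F)cc3)Cc3ccc(C(C)(C)C)cc3)cc2c1`, differs from compound 3 in one place: (trifluoromethyl)sulfanyl in place of ethoxy on an aromatic carbon. The remaining structure is shared by both compounds.

Among the compounds with values here, with no step measured, the expectation for compound 4 rests on where compound 3 stands. Compound 4 is expected to show no step beyond the scatter in this assay, a step that the limit leaves unreadable from compound 3 to compound 4. The estimate for compound 4 in this assay is 20000 nM, in the range from 8000 nM to 50000 nM, most likely again reported as a limit.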

Compound 4, half-maximal cytotoxic concentration: > 5000 nM
Compound 4: only a limit was reported (the forecaster's own chance of this, stated with the estimate: 75%); the middle value lies beyond the limit too.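

In this assay compound 4 gives > 5000 nM, which is a limit of the assay and not a number. Going by these compounds alone, compound 3 also carries only a limit, and no step between compound 3 and compound 4 can be read. The compounds shown leave open at what concentration any of them would harm these cells.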